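Cyclobutyl for Cyclopropyl in a Beagle Distribution Study

This account rests on a few compounds, and the source may have more. Where it says the series, first, only, none or still open, it means among the compounds named here.

Compound 1 `CCn1c(-c2cnc(C)nc2)nc2c(O[C@H]3CCN(C(=O)C4CC4)C3)ncnc21` and compound 2 `CCn1c(-c2cnc(C)nc2)nc2c(N[C@H]3CCN(C(=O)C4CC4)C3)ncnc21` share much of their structure; the difference between the two cores is not broken down here. In an ADME assay (Canis lupus familiaris, strain Beagle) for pharmacokinetics (on this read-out higher numbers stand for wider distribution into tissues and lower numbers for narrower distribution), compound 1 gives 0.7 L/kg, while compound 2 gives 1.8 L/kg. Compound 3 `CCn1c(-c2cnc(C)nc2)nc2c(O[C@H]3CCN(C(=O)C4CCC4)C3)ncnc21` differs from compound 1 by cyclobutyl in place of cyclopropyl on a carbonyl carbon. In this assay compound 3 gives 1.4 L/kg, so the step is a 2.0-fold higher number from compound 1 to compound 3 (0.30 log units; within the scatter). Compound 4 `CCn1c(-c2cnc(C)nc2)nc2c(N[C@H]3CCN(C(=O)C4CCC4)C3)ncnc21` carries the same change on compound 2: cyclobutyl in place of cyclopropyl on a carbonyl carbon. The account rests on a single prior step, so the expectation for compound 4 follows a 2.0-fold higher number from compound 1 to compound 3 (0.30 log units; within the scatter) and is a 1.7-fold higher number from compound 2 to compound 4 (0.22 log units; within the scatter). Compound 4 is therefore estimated at 3 L/kg in this assay, expected to lie between 1.5 L/kg and 6 L/kg.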

Compound 4, volume of distribution: 2.3 L/kg
Beside the measured number, compound 4's estimate is 1.3-fold (0.12 log units) above it, and the stated range covers the measured number.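

On the core of compound 2, cyclobutyl in place of cyclopropyl on a carbonyl carbon gives a 1.3-fold higher number from compound 2 to compound 4 (0.11 log units; within the scatter) in this assay. Set beside the earlier step, the change reads alike on the two cores, with no difference that can be told apart: the same change on two cores in this assay, a 2.0-fold higher number (0.30 log units; within the scatter) from compound 1 to compound 3 and a 1.3-fold higher number (0.11 log units; within the scatter) from compound 2 to compound 4, 1.6-fold (0.19 log units) apart, within the scatter of two such steps. This shows agreement between two cores only; as each step lies within the scatter, it does not show that the change shifts distribution on either core, nor that the agreement would hold on other cores in the series.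

The compounds shown carry only cyclopropyl or cyclobutyl on that carbonyl carbon. From the compounds shown here alone, how a cyclopentyl ring, an open chain such as isopropyl or an amine would read there remains open.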